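Chloro-to-fluoro swap on two benzotriazole-linked oxadiazole cores

The source may report more compounds than this note shows. Statements on the series, on what has been measured and on what is new or still open speak of the compounds shown alone.

Three compounds have been measured in a functional assay on HepG2 cells (Homo sapiens) for antiproliferative activity, read by MTT assay, with a stated time of 24 h; a lower number here means a stronger inhibitor, a higher number a weaker inhibitor:

compound 1, `Clc1cccc(Cc2nnc(Cn3nnc4ccccc43)o2)c1`, gives 401000 nM
compound 2, `Fc1cccc(Cc2nnc(Cn3nnc4ccccc43)o2)c1`, gives 368000 nM
compound 3, `Clc1cccc(-c2nnc(Cn3nnc4ccccc43)o2)c1`, gives 440000 nM

Compound 1 and compound 2 share a core and differ by fluoro in place of chloro on an aromatic carbon. This change made the step of a 1.1-fold lower number from compound 1 to compound 2 (0.04 log units; within the scatter). Compound 3 carries a different core; how the core of compound 3 differs from the core of compound 1 is not broken down here, and the two values of compound 1 and compound 3 stand within the scatter of each other.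

Compound 4, `Fc1cccc(-c2nnc(Cn3nnc4ccccc43)o2)c1`, has not yet been measured. Going by the values given here, it differs from compound 3 by fluoro in place of chloro on an aromatic carbon, the same change, at the same place, as the one from compound 1 to compound 2. Because the measured step of a 1.1-fold lower number from compound 1 to compound 2 (0.04 log units; within the scatter) stayed within the scatter, the step from compound 3 to compound 4 is expected to be about a 1.1-fold lower number from compound 3 to compound 4 (0.04 log units; within the scatter) in this assay as well. On that basis compound 4 is estimated to give 400000 nM, with a likely range from 250000 nM to 650000 nM.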

Compound 4, half-maximal inhibitory concentration: 451000 nM
Compound 4: middle estimate off by 1.1-fold (0.05 log units), on the low side, within the range that was stated.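

The exchange of 3-chlorophenyl for 3-fluorophenyl gave a 1.0-fold higher number from compound 3 to compound 4 (0.01 log units; within the scatter) in this assay and so left no readable change on the core of compound 3. Going by these compounds alone, this does not show that fluoro and chloro are interchangeable in general, since the change was tried at only one place and on only two closely related cores, and a step that cannot be told from the scatter on either core gives no sizeable effect whose transfer could be tested. What it does show is that this small change behaved alike on both cores, with nothing to set the two steps apart: the same change on two cores in this assay, a 1.1-fold lower number (0.04 log units; within the scatter) from compound 1 to compound 2 and a 1.0-fold higher number (0.01 log units; within the scatter) from compound 3 to compound 4, 1.1-fold (0.05 log units) apart, within the scatter of two such steps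

The compounds shown leave open whether any group other than these two halogens would move the number at this place, for example an amine, a carboxylic acid or a methoxy group. They also leave open whether the exchange would stay as small on a core carrying a longer chain.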